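Nitrophenyl in Place of Acetylphenyl on an Aminothiophene Ester

The source may hold more compounds than are shown below. What is called first, only, known or untested is meant among the compounds shown, and "the series" means these compounds.

Compound 2 `CCOC(=O)c1c(N)sc(-c2cccc(C(C)=O)c2)c1-c1cccc(C(F)(F)F)c1` was examined in a functional assay on CHO-K1 cells for agonist activity at adenosine receptor A1 (Homo sapiens), read by GTPgammaS binding; on this read-out lower numbers stand for an effect already at smaller amounts and higher numbers for an effect only at larger amounts of compound. In this assay compound 2 gives only a limit, > 10 uM, and not a number. Compound 1 `Nc1sc(-c2ccc([N+](=O)[O-])cc2)c(-c2cccc(C(F)(F)F)c2)c1C(=O)c1ccccc1` likewise gives only a limit in this assay, > 10 uM. Both values sit at the limit of > 10 uM in this assay, at which 2 of the 2 values shown sit, so neither compound provides a number to anchor a comparison.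

Compound 3 `CCOC(=O)c1c(N)sc(-c2ccc([N+](=O)[O-])cc2)c1-c1cccc(C(F)(F)F)c1` has not yet been measured. It differs from compound 2 by 4-nitrophenyl in place of 3-acetylphenyl on an aromatic carbon. For the measured compounds named here, compound 1 already carries the 4-nitrophenyl group that enters here, but it differs from compound 3 in a second place as well, so its value shows only that this group is compatible with a limit.

With no measured step between the compounds shown, the change is expected to bring no shift beyond the scatter. The step is expected to be a step that the limit leaves unreadable from compound 2 to compound 3. Compound 3 is therefore estimated at 20 uM, within 5 uM to 100 uM.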

Compound 3, concentration for half-maximal effect: > 10 uM
Compound 3 was reported as a limit (the forecaster's own chance of this, stated with the estimate: 80%); the middle value is on the limit's open side.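

In this assay, for the compounds shown here, compound 3 gives > 10 uM, again only a limit, so no step from compound 1 or compound 2 to compound 3 can be read: the limit of > 10 uM in this assay, at which 3 of the 3 values shown sit.

The compounds shown leave open whether either change alters the effect in this assay at all.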